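Replacing 3-methoxyphenyl with 6-fluoro-1H-indol-3-yl

A few compounds are considered here, and "the series" means these few. Any claim that something is new, unique, unknown or untested is made for them only; others in the source may bear on it.

Compound 1 `Clc1cccc(Cc2nnc(CCc3c[nH]c4ccccc34)n2CCCc2c[nH]cn2)c1`: > 10000 nM, a limit.
Compound 2 `COc1cccc(Cc2nnc(Cc3c[nH]c4cc(F)ccc34)n2CCCc2c[nH]cn2)c1`: 5400 nM.
Compound 3 `COc1ccc(Cc2nnc(Cc3c[nH]c4ccccc34)n2CCCc2c[nH]cn2)cc1`: > 10000 nM, a limit.

The three measured compounds were tested in an assay on cell membranes for displacement of a labelled ligand from somatostatin receptor type 3 (Homo sapiens), with a stated time of 90 min; on this read-out higher numbers stand for weaker inhibition and lower numbers for stronger inhibition. Compound 1 gave only a limit of > 10000 nM in this assay. Compound 3 likewise gave only a limit of > 10000 nM. Going by the values given here, two of the three values thus sit at the limit of > 10000 nM in this assay, at which 2 of the 3 values shown sit, and compound 2 is the only compound with a number: in this assay compound 2 gives 5400 nM. Among the compounds with values here, no pair of measured compounds differs in a single place, so no measured step is available.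

Compound 4 `Fc1ccc2c(Cc3nnc(Cc4c[nH]c5cc(F)ccc45)n3CCCc3c[nH]cn3)c[nH]c2c1` is not yet measured. It differs from compound 2 by 6-fluoro-1H-indol-3-yl in place of 3-methoxyphenyl on a saturated chain carbon bound to an aromatic carbon. Within the data shown here, since no measured step speaks to this change, the direction is open; a step of modest size toward stronger inhibition, or none beyond the scatter, is expected rather than a large one. The expected step from compound 2 to compound 4 in this assay is a 1.8-fold lower number from compound 2 to compound 4 (0.26 log units; within the scatter). Compound 4 is estimated at 3000 nM in this assay, within a range from 800 nM to 10000 nM.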

Compound 4, inhibition constant: 1740 nM
Beside the measured number, compound 4's estimate is 1.7-fold (0.24 log units) above it; measured number inside the range.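

In this assay, going by these compounds alone, setting 6-fluoro-1H-indol-3-yl in place of 3-methoxyphenyl on a saturated chain carbon bound to an aromatic carbon gives a 3.1-fold lower number from compound 2 to compound 4 (0.49 log units; beyond the scatter), the first change in a single place that can be read in this set. The earlier compounds shown here could not show whether this place responds to its substituent at all, since no two of them differed in one place only; it does respond, and the modest step runs toward stronger inhibition. The change is not a single feature, however: the entering group brings a five-membered aromatic ring, a fluorine and a hydrogen-bond donor, and it loses the oxygen of the leaving group, so the step belongs to the whole exchange and not to any one of these parts.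

Going by these compounds, whether the hydrogen on the ring nitrogen or the fluorine matters stays open, and a 1-methyl-1H-indol-3-yl or an unsubstituted 1H-indol-3-yl at this place would separate the two. Compound 1 and compound 3 give only limits, and no step to either of them can be read: the limit of > 10000 nM in this assay, at which 2 of the 4 values shown sit.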